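Amide aryl swap: nitro for methyl on the phenyl

A few compounds are considered here, and "the series" means these few. Any claim that something is new, unique, unknown or untested is made for them only; others in the source may bear on it.

Within the data shown here, compound 2 `Cc1cccc(C(=O)Nc2ccc3[nH]cc(C4CCN(C)CC4)c3n2)c1` gives 1200 nM in an assay for binding affinity to 5-hydroxytryptamine receptor 1B (Homo sapiens), read by radioligand binding (a higher number here means a weaker inhibitor, a lower number a stronger inhibitor), the lower of the two numbers so far, though compound 1 `CN1CCC(c2c[nH]c3ccc(NC(=O)C4CC4)nc23)CC1` at 1700 nM sits within the scatter of it. Among the measured compounds shown here, the single measured step, a 1.4-fold lower number from compound 1 to compound 2 (0.15 log units; within the scatter), exchanged the group on the carbonyl carbon and barely moved the number. Compound 3 `CN1CCC(c2c[nH]c3ccc(NC(=O)c4ccc([N+](=O)[O-])cc4)nc23)CC1` carries 4-nitrophenyl in place of 3-methylphenyl on a carbonyl carbon. For the measured compounds named here, only that step bears on this change, and it stayed within the scatter, so no shift beyond the scatter is expected in this assay for compound 3. Compound 3 is therefore estimated at 1200 nM, range 450 nM to 3200 nM, an expected step of no change at the digits printed from compound 2 to compound 3 (within the scatter).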

Compound 3, inhibition constant: 270 nM
The estimate for compound 3 lay 4.4-fold (0.65 log units) above the measured number; the whole stated range lies above it.
By their numbers in this assay, from the lowest: compound 3; then compounds 2 and 1 (each within the scatter of the next).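

In this assay the group on the carbonyl carbon can move the number beyond the scatter: 4-nitrophenyl gives a 4.4-fold lower number from compound 2 to compound 3 (0.65 log units; beyond the scatter) and a 6.3-fold lower number from compound 1 to compound 3 (0.80 log units; beyond the scatter). The earlier exchange of cyclopropyl for 3-methylphenyl showed no such shift, so an aromatic ring alone does not account for the change within these compounds. No measurement bearing on the origin of this shift is available.

Compound 3 differs from compound 2 in both the substituent and its location on the phenyl, and the compounds shown do not separate these two changes. Going by these compounds, whether an amine or a nitrile on the phenyl would give a similar number remains open.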